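The compounds below may be only part of what the source reports. "The series", "measured", "known", "first", "only" and "open" are said of these compounds alone.

Compound 2 `Cc1cccc(Oc2ccc(CC3SC(=O)NC3=O)cc2)n1` gives the lowest of the two numbers measured in a functional assay for agonist activity at Free fatty acid receptor 1 (Homo sapiens), read by FLIPR, in the presence of a further agent that is not named here (a higher number here means that more compound is needed for the effect, a lower number that less compound is needed), where compound 2 gives 2620 nM. Its nearest neighbour is compound 1 `Cc1ccc(Oc2ccc(CC3SC(=O)NC3=O)cc2)nc1`, which in this assay gives 4470 nM; the step of a 1.7-fold lower number from compound 1 to compound 2 (0.23 log units; within the scatter) lies within the usual scatter, so the two compounds cannot be told apart on these numbers. Compound 3 `Cc1cccnc1Oc1ccc(CC2SC(=O)NC2=O)cc1` has not yet been measured. It differs from compound 2 only in the arrangement of the same atoms: 3-methylpyridin-2-yl in place of 6-methylpyridin-2-yl on an oxygen on an aromatic ring. For the measured compounds named here, the only measured step that bears on this change is the one from compound 1 to compound 2, which also moved the methyl group around the same pyridin-2-yl ring and produced a difference within the scatter. Going by the values given here, with only this step to go on, no movement beyond the scatter is expected in this assay for compound 3 either. The estimated value of compound 3 in this assay is 3000 nM, with a range from 1200 nM to 7500 nM, which corresponds to an expected step of a 1.1-fold higher number from compound 2 to compound 3 (0.06 log units; within the scatter).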

Compound 3, half-maximal effective concentration: 1090 nM
Estimate against measurement, compound 3: 2.8-fold (0.44 log units) above; the whole stated range lies above it.
By their numbers in this assay, from the lowest: compound 3; then compounds 2 and 1 (each within the scatter of the next).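

In this assay the place of the methyl group on the pyridin-2-yl ring turns out to matter: 3-methylpyridin-2-yl on the oxygen gives a 2.4-fold lower number from compound 2 to compound 3 (0.38 log units; beyond the scatter) and also a 4.1-fold lower number from compound 1 to compound 3 (0.61 log units; beyond the scatter) whereas the earlier exchange of 5-methylpyridin-2-yl for 6-methylpyridin-2-yl gave no step beyond the scatter. The two new steps are modest, but they set compound 3 apart from both other compounds, which themselves remain indistinguishable, and they do so with no change in the atoms present or in what is counted for the group. Nothing available here bears on why this arrangement of the same atoms gives the lower number.

The compounds shown leave open whether the methyl group itself contributes to the result for compound 3, since they include neither the plain pyridin-2-yl ring nor any other group in the methyl group's place, such as an ethyl, a methoxy or a chlorine. For the compounds shown here, they also leave open how 4-methylpyridin-2-yl would compare, and whether the step seen with 3-methylpyridin-2-yl would carry over to a core other than the one these compounds share.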